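A few compounds are considered here, and "the series" means these few. Any claim that something is new, unique, unknown or untested is made for them only; others in the source may bear on it.

Measured so far:
compound 1, `O=C1C=CC[C@@H]([C@H]2C[C@@H]2c2ccccc2)O1`: 34900 nM
compound 2, `O=C1CCC[C@@H]([C@H]2C[C@@H]2c2ccccc2)O1`: > 100000 nM (a limit, not a number)

Of the compounds shown here, two have been measured in a functional assay on HBL-100 cells (Homo sapiens) for antiproliferative activity, read by luminescence and CellTiter-Glo, with a stated time of 48 h; on this read-out lower numbers stand for stronger inhibition and higher numbers for weaker inhibition. Among the compounds with values here, compound 1 gives 34900 nM in this assay, and this is the only actual number in the set. Compound 2 reached only the limit of this assay: compound 2 gives > 100000 nM, which is a limit rather than a number, as described by the limit of > 100000 nM in this assay, at which 1 of the 2 values shown sits. Within the data shown here, no step between two measured compounds has been counted here, so there is no measured step to lean on.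

The step followed here leads from compound 1 to compound 3, `O=C1C=CC[C@H]([C@H]2C[C@@H]2c2ccccc2)O1`. the two compounds have the same atoms and bonds and differ only in configuration as drawn: 1 of 3 stereo elements differ; a stereocentre at a saturated ring carbon is drawn S in compound 1 and R in compound 3 Nothing is added and nothing removed; only the configuration at one ring carbon changes. Among the measured compounds shown here, with no measured step to compare, the size and direction of this change in this assay are open; a change of configuration can leave the number where it stands or move it either way beyond the scatter. Because compound 1 gives 34900 nM, compound 3 is expected to land near it, at an estimated 40000 nM (range 10000 nM to 100000 nM). The expected step from compound 1 to compound 3 is a 1.1-fold higher number from compound 1 to compound 3 (0.06 log units; within the scatter), with a real chance that compound 3 also only reaches the limit.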

Compound 3, half-maximal inhibitory concentration: 14400 nM
Compound 3: middle estimate off by 2.8-fold (0.44 log units), on the high side; measured number inside the range.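

In this assay, changing one stereocentre at a saturated ring carbon from S to R gives a 2.4-fold lower number from compound 1 to compound 3 (0.38 log units; beyond the scatter), so the read-out at this position responds to how the atoms are arranged in space and not only to which atoms are present. The earlier compounds shown here could not show this, since no pair among them differed in configuration alone. The step is modest and rests on a single pair, but it can be assigned to this one carbon because nothing else separates the two compounds: the fact that compounds 1 and 3 differ only in the configuration as drawn

On these data alone, compound 2 gives > 100000 nM, which is a limit and not a number, so it remains open how the R arrangement at this carbon would read on the core of compound 2. Also open, as far as these compounds go, are the effect of the two stereo elements that stay the same in this pair and whether an amine or a carboxylic acid added to the core of compound 3 would move the number in either direction.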